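Methyl for hydrogen on the core: cytotoxicity expected

The compounds below may be only part of what the source reports. "The series", "measured", "known", "first", "only" and "open" are said of these compounds alone.

Measured compounds:
compound 1 `COc1ccc(C(=O)CSc2nc(Cc3cccc(Br)c3)c(C)c(=O)[nH]2)cc1`: >= 196000 nM
compound 2 `COc1ccc(C(=O)CSc2nc(Cc3ccc(Br)cc3)c(C)c(=O)[nH]2)cc1`: > 272000 nM

In an ADME assay on MT4 cells (Homo sapiens) for cytotoxicity (a higher number here means that more compound is tolerated, a lower number that less compound is tolerated), compound 1 stands only at a limit, >= 196000 nM, which is a limit of the assay and not a number. Compound 2 likewise stands at a limit, > 272000 nM. For the measured compounds named here, the one measured step, a step that the two limits leave unreadable from compound 1 to compound 2, is therefore not readable in size, as both values sit at limits (the limit of > 272000 nM in this assay, at which 1 of the 2 values shown sits; (the limit of >= 196000 nM in this assay, at which 1 of the 2 values shown sits)).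

Compound 3 `CCc1c(Cc2cccc(Br)c2)nc(SCC(=O)c2ccc(OC)cc2)[nH]c1=O` differs from compound 1 by methyl in place of hydrogen on a saturated chain carbon bound to an aromatic carbon, so that the methyl on the core of compound 1 becomes an ethyl. Going by the values given here, no measured step in this assay concerns this change, and the only step available does not give a readable size. Nothing in the two measured compounds points to a step beyond the scatter in this assay, so a step that the limit leaves unreadable from compound 1 to compound 3 from compound 1 to compound 3 is expected, most likely again reported as a limit. Compound 3 is thus estimated at 200000 nM in this assay, within a range from 60000 nM to 600000 nM.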

Compound 3, half-maximal cytotoxic concentration: 142000 nM
For compound 3 the middle estimate is 1.4-fold (0.15 log units) above the measured one; measured number inside the range.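

In this assay, for the compounds shown here, compound 3 gives 142000 nM, the only value shown that is a number and not a limit of the assay. It thus gives the series its first readable point at this position, a saturated chain carbon bound to an aromatic carbon. The change from methyl to ethyl there comes with an at least 1.3-fold lower number from compound 1 to compound 3 (0.13 log units; that floor lies within the scatter), and this size is only a floor because compound 1 stands at a limit of the assay and not at a number: the limit of >= 196000 nM in this assay, at which 1 of the 3 values shown sits.

The true size of this step therefore remains open, and the compounds shown cannot tell whether it reaches beyond the scatter. Also open, going by these compounds, are how a longer chain such as propyl, an amine or a carboxylic acid at this position would read in this assay, and whether ethyl would give a similar reading with the 4-bromophenyl group of compound 2.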